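Flipping one ring stereocentre in a peroxide acid

The compounds below may be only part of what the source reports. "The series", "measured", "known", "first", "only" and "open" are said of these compounds alone.

Of the compounds shown here, three have been measured in a functional assay on SK-MEL-2 cells (Homo sapiens) for inhibition; a higher number here means a weaker inhibitor of growth, a lower number a stronger inhibitor of growth. Compound 1 `C=C1CCC[C@H]2[C@](C)(CCC(C)=O)[C@@H](C)CC[C@]12C` reports only a limit, > 15000 nM, not a number. Compound 2 `C=C1CCCC(C)(C)C1CC[C@]1(C)CC[C@H]([C@@H](C)C(=O)OC)OO1` gives 8280 nM. Compound 3 `CC1=C(CC/C(C)=C/CC[C@@]2(C)CC[C@@H]([C@H](C)C(=O)O)OO2)C(C)(C)CCC1` also reports only a limit, > 100000 nM, and so sits at the weak end of what is shown, with no exact number available. Compound 4 `CC1=C(CC/C(C)=C/CC[C@@]2(C)CC[C@H]([C@H](C)C(=O)O)OO2)C(C)(C)CCC1` is the next compound and has not been measured; it differs from compound 3 in this way: the two compounds have the same atoms and bonds and differ only in configuration as drawn: 1 of 4 stereo elements differ; a stereocentre at a saturated ring carbon is drawn S in compound 3 and R in compound 4. Among the compounds with values here, no pair of measured compounds here differs in a single place, so there is no measured step to lean on. A change of configuration alone is expected to move this assay little, and the step of an at least 1.6-fold lower number from compound 3 to compound 4 (0.22 log units; that floor lies within the scatter) is expected to stay near the scatter, so compound 4 is estimated at 60000 nM, within 15000 nM to 200000 nM.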

Compound 4, concentration for 50% growth inhibition: > 5000 nM
Compound 4: only a limit was reported (the forecaster's own chance of this, stated with the estimate: 60%); the middle value lies beyond the limit too.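

Compound 3 and compound 4 each give only a limit in this assay, and the step between them cannot be read. As far as these compounds go, whether changing the ring stereocentre from S in compound 3 to R in compound 4 alters growth inhibition at all stays open.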